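The source may hold more compounds than are shown below. What is called first, only, known or untested is meant among the compounds shown, and "the series" means these compounds.

Compound 1, `COc1ncnc2c1c(-c1ccsc1)cn2[C@@H]1O[C@H](CO)[C@@H](O)[C@H]1O` — 140 nM in a functional assay on HCT-116 cells (Homo sapiens), read by MTT assay, with a stated time of 72 h; on this read-out higher numbers stand for weaker inhibition and lower numbers for stronger inhibition.
Compound 2, `CN(C)c1ncnc2c1c(-c1ccsc1)cn2[C@@H]1O[C@H](CO)[C@@H](O)[C@H]1O` — > 20000 nM in this assay, a limit of the assay rather than a number.
Compound 3, `COc1nc(N)nc2c1c(-c1ccsc1)cn2[C@@H]1O[C@H](CO)[C@@H](O)[C@H]1O` — > 20000 nM in this assay, likewise a limit.

Among the three measured compounds, compound 1 gives the only actual number; the other two values are limits, as the limit of > 20000 nM in this assay, at which 2 of the 3 values shown sit, records. Compound 1 therefore stands alone as the sole point from which a value can be read.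

Compound 4, `COc1ncnc2c1c(I)cn2[C@@H]1O[C@H](CO)[C@@H](O)[C@H]1O`, differs from compound 1 in one place: iodo in place of thiophen-3-yl on an aromatic carbon.

The two measured steps both change the six-membered ring of the shared core rather than the five-membered ring that carries the group exchanged here. The step of an at least 140-fold higher number from compound 1 to compound 2 (2.15 log units; beyond the scatter) and the step of an at least 140-fold higher number from compound 1 to compound 3 (2.15 log units; beyond the scatter) show that this series can lose activity sharply, but neither concerns the position where the thiophen-3-yl leaves and the iodo enters. Among the measured compounds shown here, no measured step bears directly on the change from compound 1 to compound 4, so the expectation rests on the structural change alone and is uncertain.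

Compound 4 is expected to show a modest weakening, a 2.9-fold higher number from compound 1 to compound 4 (0.46 log units; beyond the scatter), with a wide margin. The estimate for compound 4 in this assay is 400 nM, in the range 50 nM to 5000 nM.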

Compound 4, half-maximal inhibitory concentration: > 20000 nM
Compound 4: only a limit was reported; the forecaster's own chance of this, stated with the estimate: 10%; middle value at least 50-fold (1.69 log units) away from the limit.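

The thiophen-3-yl position now has a measured step of its own: putting iodo in its place gives an at least 140-fold higher number from compound 1 to compound 4 (2.15 log units; beyond the scatter). Activity in this assay therefore depends on this group on the five-membered aromatic ring, as well as on the places changed in compound 2 and compound 3, and a lone iodo does not replace it. This step rests on a limit, so its full size remains unknown, and compound 1 is still the only compound with an actual number, as each single change shown from it ends at the same limit: the limit of > 20000 nM in this assay, at which 3 of the 4 values shown sit.

Iodo differs from thiophen-3-yl in several ways at once, with one heavy atom in place of five and no ring, so these compounds cannot tell whether compound 1 relies on having a ring at this place or on the sulfur within it. A phenyl ring, a furan-3-yl group or a short chain such as ethyl at this place would separate those possibilities, while the limit leaves open how far activity falls with each change and which change costs the most.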